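This account rests on a few compounds, and the source may have more. Where it says the series, first, only, none or still open, it means among the compounds named here.

Of the compounds shown here, three have so far been tested in a functional assay on U-87MG ATCC cells for antiproliferative activity against U-87 MG (Homo sapiens), read by MTT assay, with a stated time of 48 h, tested at 100 uM; on this read-out higher numbers stand for a weaker effect at the one concentration tested and lower numbers for a stronger effect. Compound 1 `COc1ccc(-c2nc(C)c(C(=O)CSc3nc(N)c(C#N)c(-c4ccc(Cl)cc4)n3)s2)cc1` gives 3.9%. Compound 2 `COc1ccc(-c2nc(C)c(C(=O)CSc3nc(N)c(C#N)c(-c4ccccc4)n3)s2)cc1` gives 5.25%. Compound 3 `Cc1nc(-c2ccccc2)sc1C(=O)CSc1nc(N)c(C#N)c(-c2ccc(Cl)cc2)n1` gives 17.1%. Compound 3 and compound 1 differ in one place, (methoxy in place of hydrogen on an aromatic carbon), and this change made a step of a number 13.2 percentage points lower from compound 3 to compound 1 (beyond the scatter). Hydrogen in place of chloro on an aromatic carbon gave a step of a number 1.4 percentage points higher from compound 1 to compound 2 (within the scatter). The difference between the core of compound 2 and the core of compound 3 is not broken down here.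

Compound 4 `COc1ccc(-c2nc(C)c(C(=O)CSc3nc(N)c(C#N)c(-c4ccc(OC)cc4)n3)s2)cc1` has not yet been measured in this assay. Among the compounds with values here, it differs from compound 2 by methoxy in place of hydrogen on an aromatic carbon, which is the same change as the one from compound 3 to compound 1, at the same kind of place. Because of the step of a number 13.2 percentage points lower from compound 3 to compound 1 (beyond the scatter), a lower number is expected for compound 4. Compound 2, however, already stands close to the bottom of the scale with 5.25%, which leaves little room. For compound 4 the expected step is therefore only a number 2.3 percentage points lower from compound 2 to compound 4 (within the scatter). The estimate for compound 4 is 3%, between 0% and 12%.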

Compound 4, a percentage reported as activity, at one concentration (the size of the read-out at that concentration, not a potency): 0.26%
Beside the measured number, compound 4's estimate is 2.7 percentage points above it; low and high end bracket the measured number.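

In this assay, methoxy in place of hydrogen gives a number 5 percentage points lower from compound 2 to compound 4 (within the scatter), and methoxy in place of chloro gives a number 3.6 percentage points lower from compound 1 to compound 4 (within the scatter), so neither new step can be told apart from the ordinary spread of repeated measurements. Set side by side, the two cases of the hydrogen-to-methoxy change do not differ by more than that spread allows: the same change on two cores in this assay, a number 13.2 percentage points lower (beyond the scatter) from compound 3 to compound 1 and a number 5 percentage points lower (within the scatter) from compound 2 to compound 4, 8.2 percentage points apart, within the scatter of two such steps. Within the data shown here, this shows no detectable dependence on the core across these two pairs, but it does not show that the change acts equally on every core, as only two pairs are available and the new step alone cannot be told from the scatter.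

At the place where compound 1, compound 2 and compound 4 differ, the compounds shown carry only chloro, hydrogen and methoxy, so the effect of an amine, a carboxylic acid or a longer chain such as butoxy remains open. Each compound also has a read-out at a single concentration, which shows only a stronger or weaker effect at that concentration.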